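Ring Size on the Sugar Arm and Adenosine Receptor Binding

The source may report more compounds than this note shows. Statements on the series, on what has been measured and on what is new or still open speak of the compounds shown alone.

Measured compounds:
compound 1, `CC(C)NC(=O)OC[C@H]1OC(n2cnc3c(NC4CCOC4)ncnc32)[C@H](O)[C@@H]1O`, 78 nM
compound 2, `O[C@@H]1[C@@H](CO/C(S)=N/C2CCCC2)OC(n2cnc3c(NC4CCOC4)ncnc32)[C@@H]1O`, 72 nM

In an assay on DDT1 cells (Cricetulus griseus) for binding affinity to adenosine receptor A1 (Homo sapiens), read by radioligand binding (a higher number here means a weaker inhibitor, a lower number a stronger inhibitor), compound 2 gives the lowest of the two numbers, with compound 1 close by; the step of a 1.1-fold lower number from compound 1 to compound 2 (0.03 log units; within the scatter) is within the scatter. Compound 3, `O[C@@H]1[C@@H](CO/C(S)=N/C2CCCCC2)OC(n2cnc3c(NC4CCOC4)ncnc32)[C@@H]1O`, differs from compound 2 by cyclohexyl in place of cyclopentyl on a double-bonded nitrogen, a cyclohexyl in place of a cyclopentyl on a double-bonded nitrogen. Among the compounds with values here, no measured step probes this ring enlargement directly; the one measured step, a larger rebuild of the same arm, stayed within the scatter. A change within the scatter is therefore expected, a 1.2-fold lower number from compound 2 to compound 3 (0.08 log units; within the scatter). For compound 3 in this assay the estimate is 60 nM, between 25 nM and 150 nM.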

Compound 3, inhibition constant: 253 nM
For compound 3 the middle estimate is 4.2-fold (0.62 log units) below the measured one; the whole stated range lies below it.
By their numbers in this assay, from the lowest: compounds 2 and 1 (each within the scatter of the next); then compound 3.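

In this assay this position turns out to be sensitive to ring size: cyclohexyl in place of cyclopentyl on a double-bonded nitrogen gives a 3.5-fold higher number from compound 2 to compound 3 (0.55 log units; beyond the scatter), a step beyond the scatter. The earlier pair had suggested a tolerant arm, yet compound 3 also loses ground against the shorter, ring-free arm, with a 3.2-fold higher number from compound 1 to compound 3 (0.51 log units; beyond the scatter). So the arm tolerates cyclopentyl but not every ring placed there.

From the compounds shown here alone, whether a smaller cyclobutyl ring or an open pentyl chain would fare like cyclopentyl remains open. No evidence here explains the loss seen with cyclohexyl.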